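Two Limits and an Untested Aryl Swap

The source may report more compounds than this note shows. Statements on the series, on what has been measured and on what is new or still open speak of the compounds shown alone.

Compound 1 `CC1CCN(C2CCN(S(=O)(=O)c3cccc(-c4ccccc4F)c3)CC2)CC1` was examined in an ADME assay on HCT-116 cells (Homo sapiens) for cytotoxicity, read by CellTiter-Glo, with a stated time of 72 h; a lower number here means a stronger inhibitor, a higher number a weaker inhibitor. There compound 1 gives only a limit of the assay, > 5000 nM, rather than a number. Compound 2 `Cc1cc(C)c(S(=O)(=O)N2CCC(C(=O)N3CCC(C)CC3)CC2)c(C)c1` likewise reaches only a limit in this assay, at > 5000 nM. Both results rest at the limit of > 5000 nM in this assay, at which 2 of the 2 values shown sit, so compound 1 stands level with the one other compound shown. Compound 3 `Cc1cc(C)cc(-c2cccc(S(=O)(=O)N3CCC(N4CCC(C)CC4)CC3)c2)c1` carries 3,5-dimethylphenyl in place of 2-fluorophenyl on an aromatic carbon. Among the measured compounds shown here, no measured step informs this change, so no shift beyond the scatter is expected in this assay. The expected step is a step that the limit leaves unreadable from compound 1 to compound 3. Compound 3 is estimated at 8000 nM in this assay, with a range from 2500 nM to 30000 nM.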

Compound 3, half-maximal inhibitory concentration: > 5000 nM
Compound 3 ended at the assay's limit; the forecaster's own chance of this, stated with the estimate: 80%; the middle value is on the limit's open side.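

Among the compounds shown here, compound 3, like compound 1, gives only a limit in this assay, so no step between them can be read: the limit of > 5000 nM in this assay, at which 3 of the 3 values shown sit. From the compounds shown here alone, how 3,5-dimethylphenyl and 2-fluorophenyl compare there stays open, as does where compound 1, compound 2 and compound 3 truly lie beyond that limit.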